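The source may hold more compounds than are shown below. What is called first, only, known or untested is meant among the compounds shown, and "the series" means these compounds.

Measured compounds:
compound 1 `COc1ccccc1CC1(OC)CCN(c2ccc(C(=O)NS(=O)(=O)c3ccc(N[C@H](CCN(C)C)CSc4ccccc4)c([N+](=O)[O-])c3)cc2)CC1` gives 250 nM
compound 2 `COC1(Cc2ccccc2-c2ccccc2)CCN(c2ccc(C(=O)NS(=O)(=O)c3ccc(N[C@H](CCN(C)C)CSc4ccccc4)c([N+](=O)[O-])c3)cc2)CC1` gives 20 nM
compound 3 `CN(C)CC[C@H](CSc1ccccc1)Nc1ccc(S(=O)(=O)NC(=O)c2ccc(N3CCC(=Cc4ccccc4Cl)CC3)cc2)cc1[N+](=O)[O-]` gives 450 nM

These three values come from a functional assay (FL5.12 cells, Mus musculus) with Apoptosis regulator Bcl-2 (Homo sapiens) as the target; on this read-out lower numbers stand for an effect already at smaller amounts and higher numbers for an effect only at larger amounts of compound. Compound 3 has the highest number of the three: its value and that of compound 1 lie within the scatter of each other, while compound 2 is clearly separated from both. Compound 4 `COc1ccccc1C=C1CCN(c2ccc(C(=O)NS(=O)(=O)c3ccc(N[C@H](CCN(C)C)CSc4ccccc4)c([N+](=O)[O-])c3)cc2)CC1` has not yet been measured in this assay. It differs from compound 3 in one place: methoxy in place of chloro on an aromatic carbon. Within the data shown here, the only step measured so far with one change, a 13-fold lower number from compound 1 to compound 2 (1.10 log units; beyond the scatter), concerns a different exchange, methoxy giving way to phenyl, and at a different part of the shared core, so it does not speak directly to a chloro-to-methoxy exchange. Among the measured compounds shown here, the one comparison that involves a methoxy-bearing compound, compound 1 against compound 3, shows two values within the scatter of each other, though those compounds differ in more than one place. For the measured compounds named here, with no direct precedent, the expectation is a step of a 1.3-fold lower number from compound 3 to compound 4 (0.11 log units; within the scatter), that is, no change beyond the scatter. Compound 4 is therefore estimated at 350 nM, with a range from 150 nM to 900 nM.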

Compound 4, half-maximal effective concentration: 250 nM
Compound 4: middle estimate off by 1.4-fold (0.15 log units), on the high side; low and high end bracket the measured number.
By their numbers in this assay, from the lowest: compound 2; then compounds 1, 4 and 3 (each within the scatter of the next).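

In this assay, among these compounds, the exchange of chloro for methoxy on an aromatic carbon, ortho to a large group, gives a 1.8-fold lower number from compound 3 to compound 4 (0.26 log units; within the scatter) and so provides the first direct reading at this position. The 2-chlorophenyl and 2-methoxyphenyl forms cannot be told apart on this read-out, even though the entering group brings one more heavy atom and a hydrogen-bond acceptor. Among the compounds shown here, the large step of a 13-fold lower number from compound 1 to compound 2 (1.10 log units; beyond the scatter) belongs to a different exchange on a different core, and this pair shows no step of that kind for chloro and methoxy.

From the compounds shown here alone, whether a phenyl, a hydroxyl, an amine or a carboxylic acid at this position would also leave the number within the scatter remains open. One pair also cannot show whether the same exchange would read alike on another core. No available evidence explains why these two groups read alike.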